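Series notes: aryl substituent swap from cyano to morpholinylcarbonyl

The source may report more compounds than this note shows. Statements on the series, on what has been measured and on what is new or still open speak of the compounds shown alone.

Of the compounds shown here, three of the shared core have been measured in a functional assay on HEK293 cells for agonist activity at Free fatty acid receptor 1 (Homo sapiens), read by fluorescence and calcium flux, with a stated time of 10 min; a lower number here means a smaller maximal response, a higher number a larger maximal response. Compound 1 `CC#C[C@@H](CC(=O)O)c1ccc(OC[C@H]2COc3ccc(C)cc3O2)cc1` gives 78%. Compound 2 `CC#C[C@@H](CC(=O)O)c1ccc(OC[C@H]2COc3ccc(OC)cc3O2)cc1` gives 91%. Compound 3 `CC#C[C@@H](CC(=O)O)c1ccc(OC[C@H]2COc3ccc(C#N)cc3O2)cc1` gives 60%, the lowest of the three, with the gap a number 31 percentage points lower from compound 2 to compound 3 (beyond the scatter) and the gap a number 18 percentage points lower from compound 1 to compound 3 (beyond the scatter).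

Compound 4 `CC#C[C@@H](CC(=O)O)c1ccc(OC[C@H]2COc3ccc(C(=O)N4CCOCC4)cc3O2)cc1` is not yet measured. It differs from compound 3 by (morpholin-4-yl)carbonyl in place of cyano on an aromatic carbon.

Both measured steps that end in compound 3 bear on this change, since both remove or add the cyano group: a number 18 percentage points lower from compound 1 to compound 3 (beyond the scatter) and a number 31 percentage points lower from compound 2 to compound 3 (beyond the scatter). In each case the cyano compound gave the smaller maximal response. Within the data shown here, no measured compound carries a (morpholin-4-yl)carbonyl group, so the size of the step is uncertain. A rise beyond the scatter is expected in this assay for compound 4, estimated as a number 16 percentage points higher from compound 3 to compound 4 (beyond the scatter). Compound 4 is therefore expected to reach 76%, within a range from 58% to 94%.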

Compound 4, largest response reached (Emax), in percent of the reference or control that the assay uses: 33%
For compound 4 the middle estimate is 43 percentage points above the measured one; measured number below the stated range.
By their numbers in this assay, from the lowest: compound 4; then compound 3; then compound 1; then compound 2.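

In this assay the (morpholin-4-yl)carbonyl group gives the smallest maximal response of the four compounds, and all three steps into compound 4 fall: (a number 27 percentage points lower from compound 3 to compound 4 (beyond the scatter)) and (a number 45 percentage points lower from compound 1 to compound 4 (beyond the scatter)) and (a number 58 percentage points lower from compound 2 to compound 4 (beyond the scatter)). The cyano group therefore no longer marks the low end at this aromatic carbon, and the substituent here can take the maximal response down much further than the first three compounds showed. No measured evidence accounts for this fall.

From the compounds shown here alone, it remains open whether the loss belongs to the carbonyl link or to the morpholine ring, which a primary carboxamide or a methyl ketone on the same carbon would help separate. Also open, going by these compounds, is whether ethoxy, a longer chain than methoxy, keeps the high response of compound 2.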